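Open-chain series: compound 2 to compound 3

This account rests on a few compounds, and the source may have more. Where it says the series, first, only, none or still open, it means among the compounds named here.

- compound 1 (`CC(=O)CC/C=C(\C)CCC1=C(C)CC[C@H](O)C1(C)C`) gives (> 40000 nM), a limit
- compound 2 (`C=C(C)[C@H](O)CC/C(C)=C/CC/C(C)=C/CCC(C)=O`) gives (> 40000 nM), a limit

Both entries come from a functional assay on P388 cells (Mus musculus) for antiproliferative activity, read by MTT assay, with a stated time of 72 h (a higher number here means a weaker inhibitor, a lower number a stronger inhibitor), and neither is a number. Together they amount to the limit of > 40000 nM in this assay, at which 2 of the 2 values shown sit, so the series shows no graded activity so far.

Compound 2 has only a limit (> 40000 nM), not a measured potency, and it cannot be placed any more closely than that.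

The next compound is compound 3 (`CC(=O)CC/C=C(\C)CC/C=C(\C)CC[C@@H](O)C(C)(C)O`), not yet measured. The change from compound 2 is 1-hydroxy-1-methylethyl in place of 1-methylethenyl on a saturated chain carbon bound to an oxygen on a saturated carbon and a saturated chain carbon, with 1-hydroxy-1-methylethyl in place of 1-methylethenyl on a saturated chain carbon bound to an oxygen on a saturated carbon and a saturated chain carbon.

For the measured compounds named here, no step between measured compounds is available to size this change. Going by the values given here, the only anchor is compound 2 (> 40000 nM), itself a limit, so no shift beyond the scatter is expected in this assay and a further limit is the most likely report. The expected move is small (a number no higher from compound 2 to compound 3 (the limit leaves the size open)). For compound 3 the estimated value is (40000 nM), with an expected range of (15000 nM to 80000 nM).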

Compound 3, half-maximal inhibitory concentration: > 40000 nM
Compound 3 gave a limit, no number; the forecaster's own chance of this, stated with the estimate: 80%; the middle value sits exactly at the limit.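

In this assay compound 3 gives > 40000 nM, a limit and not a number. Compound 2 is also held only by a limit, so no step can be read between compound 2 and compound 3. The series so far reduces to one figure: the limit of > 40000 nM in this assay, at which 3 of the 3 values shown sit.

The compounds shown leave open whether 1-hydroxy-1-methylethyl and 1-methylethenyl differ in potency at all.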